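The source may report more compounds than this note shows. Statements on the series, on what has been measured and on what is new or still open speak of the compounds shown alone.

Of the compounds shown here, three sharing one core have been tested in an ADME assay on HEL cells (Homo sapiens) for cytotoxicity; on this read-out lower numbers stand for higher toxicity in this test and higher numbers for lower toxicity in this test. Compound 1 `C/C(=N\NC(=O)COc1cccc2ccccc12)c1ccc(O)cc1O` carries a 2,4-dihydroxyphenyl group. In this assay compound 1 gives > 100 ug/mL, which is a limit of the assay rather than a number. Compound 2 `C/C(=N\NC(=O)COc1cccc2ccccc12)c1ccc([N+](=O)[O-])cc1` carries a 4-nitrophenyl group, and in this assay compound 2 gives 100 ug/mL. Compound 3 `C/C(=N\NC(=O)COc1cccc2ccccc12)c1ccc(Cl)cc1` carries a 4-chlorophenyl group. In this assay compound 3 gives >= 4 ug/mL, again a limit and not a number. Because one value sits at the limit of > 100 ug/mL in this assay, at which 1 of the 3 values shown sits, and another at the limit of >= 4 ug/mL in this assay, at which 1 of the 3 values shown sits, the steps of a number no higher from compound 1 to compound 2 (the limit leaves the size open), a step that the two limits leave unreadable from compound 1 to compound 3 and a step that the limit leaves unreadable from compound 2 to compound 3 cannot be read in size. Within the data shown here, compound 3 thus stands only at a limit, and the one further value shown beside it is a limit too. Among the measured compounds shown here, compound 4 `C/C(=N\NC(=O)COc1cccc2ccccc12)c1ccccc1O` has not yet been measured. 2-hydroxyphenyl in place of 4-chlorophenyl on a carbon with a double bond to nitrogen None of the measured steps has a readable size, so no step beyond the scatter can be expected in either direction from compound 3 to compound 4. Compound 4 is expected to give about 50 ug/mL, within a range from 10 ug/mL to 100 ug/mL. The step that the limit leaves unreadable from compound 3 to compound 4 is what this estimate means.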

Compound 4, minimum cytotoxic concentration: 20 ug/mL
Compound 4: the middle estimate sits 2.5-fold (0.40 log units) above what was measured; the measured number falls inside the stated range.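

In this assay, among these compounds, the 2-hydroxyphenyl group on the carbon with a double bond to nitrogen gives the first step here with a readable size, measured against 4-nitrophenyl (a 5.0-fold lower number from compound 2 to compound 4 (0.70 log units; beyond the scatter)). Taking one hydroxy away from the 2,4-dihydroxyphenyl group also lowers the number (an at least 5.0-fold lower number from compound 1 to compound 4 (0.69 log units; beyond the scatter)), and that size stays open on one side, as the value of compound 1 is a limit, so carrying a hydroxy does not alone keep the number high in these compounds. The steps that involve compound 3 still cannot be read: the limit of >= 4 ug/mL in this assay, at which 1 of the 4 values shown sits.

The compounds shown leave open whether the lower number belongs to the hydroxy itself or to the ring as a whole. A phenyl ring with a methoxy group or an amine in place of that hydroxy would help separate the two.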